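A few compounds are considered here, and "the series" means these few. Any claim that something is new, unique, unknown or untested is made for them only; others in the source may bear on it.

The series shares a core seen in compound 2 `NS(=O)(=O)NCCSc1nonc1/C(=N/O)Nc1ccc(F)c(Br)c1`, which in an assay for inhibition of Indoleamine 2,3-dioxygenase 1 (Homo sapiens), read by fluorescence, with a stated time of 24 h (on this read-out higher numbers stand for weaker inhibition and lower numbers for stronger inhibition), gives 2.8 nM, the lowest of the three numbers recorded. Compound 1 `NS(=O)(=O)CC(=O)NCCSc1nonc1/C(=N/O)Nc1ccc(F)c(Br)c1` gives 12 nM and compound 3 `CS(=N)(=O)CC(=O)NCCSc1nonc1/C(=N/O)Nc1ccc(F)c(Br)c1` gives 14 nM; the steps of a 4.3-fold lower number from compound 1 to compound 2 (0.63 log units; beyond the scatter) and a 5.0-fold higher number from compound 2 to compound 3 (0.70 log units; beyond the scatter) separate compound 2 from both, while a 1.2-fold higher number from compound 1 to compound 3 (0.07 log units; within the scatter). Compound 4 `NS(=O)(=O)NCCOc1nonc1/C(=N/O)Nc1ccc(F)c(Br)c1` carries 2-(sulfamoylamino)ethoxy in place of (2-(sulfamoylamino)ethyl)sulfanyl on an aromatic carbon. Among the measured compounds shown here, none of the measured steps touches this position: all three vary the sulfamoyl end of the chain and leave the atom joining the chain to the ring unchanged. For the measured compounds named here, no measured step therefore bears directly on this change, and the expected result is a small step, a 1.8-fold higher number from compound 2 to compound 4 (0.25 log units; within the scatter), with no firm direction. Compound 4 is expected near 5 nM, in the range 1.5 nM to 15 nM.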

Compound 4, half-maximal inhibitory concentration: 12 nM
For compound 4 the middle estimate is 2.4-fold (0.38 log units) below the measured one, within the range that was stated.
By their numbers in this assay, from the lowest: compound 2; then compounds 1, 4 and 3 (each within the scatter of the next).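

The atom joining the chain to the shared core is not neutral in this assay: 2-(sulfamoylamino)ethoxy in place of (2-(sulfamoylamino)ethyl)sulfanyl gives a 4.3-fold higher number from compound 2 to compound 4 (0.63 log units; beyond the scatter), although both groups count the same hydrogen-bond donors and acceptors. Among the compounds shown here, this is the only measured step at this position, as the earlier steps all vary the sulfamoyl end of the chain. Nothing at hand explains the step.

Going by these compounds, whether an amine as the joining atom, or a longer chain on either atom, would match compound 2 remains open. Also open, on these data alone, is whether the steps at the sulfamoyl end carry over to the ethoxy chain.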